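Aryl swap on compound 2: what to expect for compound 3

A few compounds are considered here, and "the series" means these few. Any claim that something is new, unique, unknown or untested is made for them only; others in the source may bear on it.

Compound 2 `O=C(NC1CCN(Cc2ccc(Cl)cc2)CC1)c1ccc2ccccc2c1` and compound 1 `O=C(NC1CCN(Cc2ccc(Cl)cc2)CC1)c1cccc2ccccc12` have both been run in an assay on isolated protein for displacement of a labelled ligand from D(4) dopamine receptor (Homo sapiens); a higher number here means a weaker inhibitor, a lower number a stronger inhibitor. Compound 1 gives 43 nM and compound 2 gives 37 nM; the two numbers lie within the usual scatter of each other, so neither stands apart. Compound 3 `O=C(NC1CCN(Cc2cccc(C(F)(F)F)c2)CC1)c1ccc2ccccc2c1` has not yet been measured. It differs from compound 2 by 3-(trifluoromethyl)phenyl in place of 4-chlorophenyl on a saturated chain carbon bound to an amine nitrogen in a ring. Going by the values given here, no measured pair shows a change of this kind, so the step is expected to be a 1.6-fold higher number from compound 2 to compound 3 (0.21 log units; within the scatter) in this assay, toward a higher number if anything, not clearly beyond the scatter. Compound 3 is estimated at 60 nM, with a range of 20 nM to 200 nM.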

Compound 3, inhibition constant: 103 nM
For compound 3 the middle estimate is 1.7-fold (0.23 log units) below the measured one, and the stated range covers the measured number.
By their numbers in this assay, from the lowest: compounds 2 and 1 (each within the scatter of the next); then compound 3.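

With only the other end of the core differing between compound 1 and compound 2, this series had not yet tested the aryl group on the saturated chain carbon bound to an amine nitrogen in a ring. In this assay, 3-(trifluoromethyl)phenyl in place of 4-chlorophenyl gives a 2.8-fold higher number from compound 2 to compound 3 (0.44 log units; beyond the scatter), so this position is sensitive to at least this change. No available data account for the weaker binding.

This single step cannot separate the effect of the substituent's identity from that of its placement on the ring. From the compounds shown here alone, how an unsubstituted phenyl group would compare at this position remains open.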